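Swapping a Protected Aminomethyl for Phenyl at the Amide Carbonyl

The source may hold more compounds than are shown below. What is called first, only, known or untested is meant among the compounds shown, and "the series" means these compounds.

Compound 1 `COc1ccc(N(CC(=O)NCCC[Te]c2ccccc2)C(=O)CNC(=O)OC(C)(C)C)cc1` was tested in a functional assay on SW-620 cells (Homo sapiens) for inhibition, with a stated time of 48 h; a lower number here means that less compound is tolerated, a higher number that more compound is tolerated. In this assay compound 1 gives only a limit, < 100000 nM, so no exact number is known for it. Two related compounds do give numbers: compound 2 `COc1ccc(N(CC(=O)NCCC[Te]c2ccccc2)C(=O)CCSC2=C(C)C(=O)c3ccccc3C2=O)cc1` gives 45700 nM in this assay, and compound 3 `CC1=C(SCCC(=O)OCC(=O)NCCC[Te]c2ccccc2)C(=O)c2ccccc2C1=O` gives 60300 nM. Compound 4 `COc1ccc(N(CC(=O)NCCC[Te]c2ccccc2)C(=O)c2ccccc2)cc1` has not yet been measured. It differs from compound 1 in one place: phenyl in place of ((tert-butoxycarbonyl)amino)methyl on a carbonyl carbon. Within the data shown here, no measured pair differs in just this way, and the only anchor is the limit of < 100000 nM in this assay, at which 1 of the 3 values shown sits. The expected step is a step that the limit leaves unreadable from compound 1 to compound 4, with no clear direction beyond the scatter. Compound 4 is therefore estimated at 50000 nM, most likely between 15000 nM and 100000 nM.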

Compound 4, concentration lethal to 50% of the cells: 56200 nM
Compound 4: the middle estimate sits 1.1-fold (0.05 log units) below what was measured; low and high end bracket the measured number.
By their numbers in this assay, from the lowest: compounds 2, 4 and 3 (each within the scatter of the next).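

No step can be read from compound 1 to compound 4, since compound 1 has only a limit: the limit of < 100000 nM in this assay, at which 1 of the 4 values shown sits.

As far as these compounds go, whether phenyl in place of ((tert-butoxycarbonyl)amino)methyl changes the tolerated concentration, and in which direction, remains open.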